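Trimming the methyl from the thiazole amide

A few compounds are considered here, and "the series" means these few. Any claim that something is new, unique, unknown or untested is made for them only; others in the source may bear on it.

Compound 1 `Cc1cc(NC(=O)Cn2cc(-c3ccc(Cl)cc3)nn2)no1` gives 1910 nM in a functional assay on BMDM cells (Mus musculus, strain C57BL/6) for inhibition, with a stated time of 2 days; on this read-out higher numbers stand for weaker inhibition and lower numbers for stronger inhibition. Compound 2 `Cc1csc(NC(=O)Cn2cc(-c3ccc(Cl)cc3)nn2)n1` gives 520 nM in this assay.

For the measured compounds named here, compound 2 holds the lower of the two numbers measured so far; its only neighbour is compound 1, and the single measured step, a 3.7-fold lower number from compound 1 to compound 2 (0.57 log units; beyond the scatter), is a modest one that lies beyond the scatter. Compound 3 `O=C(Cn1cc(-c2ccc(Cl)cc2)nn1)Nc1nccs1` differs from compound 2 by hydrogen in place of methyl on an aromatic carbon. Going by the values given here, that measured step swaps one five-membered heteroaryl ring for another and leaves the methyl untouched, so no measured pair shows what removing the methyl does on this core. Among the compounds with values here, with no direct precedent, the author expects at most a step within the scatter, leaning slightly toward a higher number. For compound 3 in this assay the estimate is 800 nM, within 300 nM to 2200 nM. This estimate corresponds to an expected step of a 1.5-fold higher number from compound 2 to compound 3 (0.19 log units; within the scatter).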

Compound 3, half-maximal inhibitory concentration: 1100 nM
The estimate for compound 3 lay 1.4-fold (0.14 log units) below the measured number; measured number inside the range.
By their numbers in this assay, from the lowest: compound 2; then compounds 3 and 1 (each within the scatter of the next).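

Going from 4-methyl-1,3-thiazol-2-yl to 1,3-thiazol-2-yl gives a 2.1-fold higher number from compound 2 to compound 3 (0.33 log units; beyond the scatter) in this assay, the first measured read on this aromatic carbon, and it shows that the methyl here accounts for a modest but real part of the lower number of compound 2. For the compounds shown here, without the methyl, the choice of ring no longer separates the compounds: the step is a 1.7-fold lower number from compound 1 to compound 3 (0.24 log units; within the scatter), whereas the same ring exchange with the methyl in place, a 3.7-fold lower number from compound 1 to compound 2 (0.57 log units; beyond the scatter), lay beyond the scatter. Nothing available explains why this methyl matters.

The compounds shown leave open whether any group on this carbon would serve as well as methyl, or whether an ethyl group, a chlorine or an amine would shift the number further. Also open, from the compounds shown here alone, is what the methyl contributes on the 5-methyl-1,2-oxazol-3-yl ring of compound 1.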